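Compound 1 and a bromo exchange

The source may report more compounds than this note shows. Statements on the series, on what has been measured and on what is new or still open speak of the compounds shown alone.

Among the measured compounds shown here, in a toxicity assay on NIH3T3 cells (Mus musculus) for cytotoxicity, read by resazurin assay (on this read-out higher numbers stand for an effect only at larger amounts of compound and lower numbers for an effect already at smaller amounts), compound 1 (`COC(=O)c1ccc(NCc2cncn2Cc2ccccc2Cl)cc1-c1ccccc1`) gives 10000 nM, the only true number among the three values available. Compound 2 (`c1ccc(-c2ccc(Cn3cncc3CNc3ccc(-c4nc5ccccc5s4)c(-c4ccccc4)c3)cc2)cc1`) is reported only as a limit, > 1000 nM. Compound 3 (`c1ccc(-c2ccc(Cn3cncc3CNc3ccc(-c4cncs4)c(-c4ccccc4)c3)cc2)cc1`) is likewise reported only as a limit, > 1000 nM. Together these two entries make up (the limit of > 1000 nM in this assay, at which 2 of the 3 values shown sit). For the measured compounds named here, the one measured step, a step that the two limits leave unreadable from compound 2 to compound 3, replaces 1,3-benzothiazol-2-yl with 1,3-thiazol-5-yl, a different exchange, and its size cannot be read, so it offers no guide.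

Compound 4 (`COC(=O)c1ccc(NCc2cncn2Cc2ccccc2Br)cc1-c1ccccc1`) departs from compound 1 by bromo in place of chloro on an aromatic carbon. In words, this is bromo in place of chloro on an aromatic carbon, ortho to a large group. Going by the values given here, no measured step covers this exchange, which leaves compound 1 at 10000 nM as the sole anchor for an expectation. The expected result is no change at the digits printed from compound 1 to compound 4 (within the scatter), with no change beyond the usual scatter in this assay. Compound 4 is estimated at 10000 nM, with an expected range from 4500 nM to 20000 nM.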

Compound 4, half-maximal effective concentration: 10000 nM
For compound 4 middle estimate and measured number coincide at the digits printed; low and high end bracket the measured number.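

Among the compounds shown here, the exchange gives the first readable step in this assay, and it is no change at the digits printed from compound 1 to compound 4 (within the scatter). For the compounds shown here, the only earlier step cannot be read, as both its ends are limits, whereas this one joins two true numbers and shows that, on an aromatic carbon ortho to a large group, this read-out does not separate chloro from bromo.

The compounds shown leave open whether a group of another kind at this place, such as methoxy, an amine or a carboxylic acid, would give a different value from that of compound 1. They also leave open what a carboxylic acid in place of the methyl ester of compound 1 would do in this assay. Nothing available bears on why the exchange reads as it does.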